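A few compounds are considered here, and "the series" means these few. Any claim that something is new, unique, unknown or untested is made for them only; others in the source may bear on it.

Measured compounds in a functional assay (aorta) with Rattus norvegicus as the target; on this read-out higher numbers stand for an effect only at larger amounts of compound and lower numbers for an effect already at smaller amounts:
Compound 1 `Cc1cccc(NC(=O)NC2CC(C)(C)Oc3ccc(F)cc32)c1`. Compound 1 gives > 30000 nM, a limit of the assay rather than a number.
Compound 2 `Cc1cccc(NC(=O)NC2CC(C)(C)Oc3ccc(Cl)cc32)c1`. Compound 2 gives > 10000 nM, likewise a limit.
Compound 3 `Cc1cccc(NC(=O)NC2CC(C)(C)Oc3ccc(Br)cc32)c1`. Compound 3 gives > 10000 nM, again a limit.

Compound 2 therefore stands on a limit, and so do both other values around it: two sit at the limit of > 10000 nM in this assay, at which 2 of the 3 values shown sit, and one at the limit of > 30000 nM in this assay, at which 1 of the 3 values shown sits. None of the three measured steps can be read: a step that the two limits leave unreadable from compound 1 to compound 2, a step that the two limits leave unreadable from compound 1 to compound 3 and a step that the two limits leave unreadable from compound 2 to compound 3 are all unreadable between the limits, and all three concern only the halogen on the aromatic carbon of the shared core.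

Compound 4 `CC1(C)CC(NC(=O)Nc2ccc(Cl)cc2)c2cc(Cl)ccc2O1` differs from compound 2 in another place: 4-chlorophenyl in place of 3-methylphenyl on an amide-type nitrogen. Among the measured compounds shown here, no measured step touches the aryl group on the urea nitrogen, so the three unreadable steps bear on the change only in that they show nothing has yet produced a readable number in this assay. The step from compound 2 to compound 4 is therefore expected to be a step that the limit leaves unreadable from compound 2 to compound 4, with no direction supported beyond the scatter. Compound 4 is estimated at 20000 nM, with a range from 4000 nM to 100000 nM, and a limit rather than a number is the more likely outcome.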

Compound 4, half-maximal effective concentration: > 300000 nM
Compound 4: no number, only a limit (the forecaster's own chance of this, stated with the estimate: 70%); middle value at least 15-fold (1.17 log units) from the limit.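

In this assay compound 4 gives > 300000 nM, a limit and not a number. Compound 2 gives > 10000 nM, also a limit, and the step between compound 2 and compound 4 cannot be read. The compounds shown leave open what 4-chlorophenyl in place of 3-methylphenyl does to the read-out, and whether any compound of this series gives a number in this assay.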